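The compounds below may be only part of what the source reports. "The series", "measured", "known", "first", "only" and "open" are said of these compounds alone.

Measured so far: compound 1 `CCC(=O)c1ccc(OCCCCOc2ccc(C(=O)O)cc2C)c(C)c1O` gives 82 nM in an assay on HEK293 cells for positive allosteric modulation of metabotropic glutamate receptor 2 (Rattus norvegicus), read by thallium flux, with a stated time of 2.5 min; on this read-out lower numbers stand for an effect already at smaller amounts and higher numbers for an effect only at larger amounts of compound; compound 2 `CC(=O)c1ccc(OCCCCOc2ccc(C(=O)O)cc2C)c(C)c1O` gives 50 nM; compound 3 `Cc1cc(C(=O)O)ccc1OCCCCOc1ccc(C(=O)CC2CCCC2)c(O)c1C` gives 608 nM.

Compound 1 stands second highest of the three numbers. Its nearest neighbour is compound 2, with a 1.6-fold lower number from compound 1 to compound 2 (0.21 log units; within the scatter); its furthest is compound 3, with a 7.4-fold higher number from compound 1 to compound 3 (0.87 log units; beyond the scatter). The remaining measured step, a 12-fold higher number from compound 2 to compound 3 (1.08 log units; beyond the scatter), also sits at the saturated chain carbon bound to the carbonyl carbon. Compound 4 `CCC(=O)c1ccc(OCCCCOc2ccc(C(=O)O)cc2OC)c(C)c1O` differs from compound 1 at the other end of the shared core: methoxy in place of methyl on an aromatic carbon. Within the data shown here, no measured step touches that position, so the comparison has no direct precedent and the expectation is correspondingly uncertain. In this assay the expected step is a 1.5-fold higher number from compound 1 to compound 4 (0.17 log units; within the scatter), not clearly beyond the scatter. The estimated value for compound 4 is 120 nM, expected to lie between 40 nM and 400 nM.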

Compound 4, half-maximal effective concentration: 114 nM
Estimate against measurement, compound 4: 1.1-fold (0.02 log units) above; low and high end bracket the measured number.
By their numbers in this assay, from the lowest: compounds 2, 1 and 4 (each within the scatter of the next, the first and the last beyond it); then compound 3.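

In this assay, putting methoxy in place of methyl on this aromatic carbon, ortho to a large group and meta to a carboxy group, gives a 1.4-fold higher number from compound 1 to compound 4 (0.14 log units; within the scatter). This position therefore accepts the extra oxygen, a hydrogen-bond acceptor, with no shift that can be told from the scatter. Nothing measured here bears on the reason for this result.

Going by these compounds, whether a plain hydrogen, a chlorine atom, an amine or a longer ethoxy chain would read the same here stays open. So does whether methoxy would give a similar result on compound 2.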